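Trading the nitrile for a methyl on the biaryl

A few compounds are considered here, and "the series" means these few. Any claim that something is new, unique, unknown or untested is made for them only; others in the source may bear on it.

Compound 3 `CC(C)(N)CC(=O)N[C@@H]1CCc2ccccc2N(Cc2ccc(-c3ccccc3C#N)cc2)C1=O` holds the highest of the three numbers measured in a functional assay (Pituitary gland cell) with Rattus norvegicus as the target (a higher number here means that more compound is needed for the effect, a lower number that less compound is needed), where compound 3 gives 5 uM. Compound 2 `CC(C)(N)CC(=O)N[C@@H]1CCc2ccccc2N(Cc2ccc(-c3ccccc3S(N)(=O)=O)cc2)C1=O` gives 3 uM, and the step of a 1.7-fold higher number from compound 2 to compound 3 (0.22 log units; within the scatter) does not separate the two. Compound 1 `CC(C)(N)CC(=O)N[C@@H]1CCc2ccccc2N(Cc2ccc(-c3ccccc3-c3nnnn3Cc3ccccc3)cc2)C1=O` gives 0.7 uM, so the step of a 7.1-fold higher number from compound 1 to compound 3 (0.85 log units; beyond the scatter) is the only clear gap. Compound 4 `Cc1ccccc1-c1ccc(CN2C(=O)[C@H](NC(=O)CC(C)(C)N)CCc3ccccc32)cc1` differs from compound 3 by methyl in place of cyano on an aromatic carbon. The steps at this aromatic carbon, a 4.3-fold higher number from compound 1 to compound 2 (0.63 log units; beyond the scatter) and a 7.1-fold higher number from compound 1 to compound 3 (0.85 log units; beyond the scatter), show that the large group of compound 1 gave the lowest number, while the two smaller groups stayed close to each other. Methyl is another small group, so for compound 4 a step of a 1.4-fold higher number from compound 3 to compound 4 (0.15 log units; within the scatter) is expected. The number for compound 4 is estimated at 7 uM, with a range from 2.5 uM to 20 uM.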

Compound 4, concentration for half-maximal effect: 1 uM
Estimate against measurement, compound 4: 7.0-fold (0.85 log units) above, outside the stated range (below it).
By their numbers in this assay, from the lowest: compounds 1 and 4 (each within the scatter of the next); then compounds 2 and 3 (each within the scatter of the next).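

In this assay methyl in place of cyano gives a 5.0-fold lower number from compound 3 to compound 4 (0.70 log units; beyond the scatter) and methyl in place of sulfamoyl gives a 3.0-fold lower number from compound 2 to compound 4 (0.48 log units; beyond the scatter) so small groups at this aromatic carbon do not all read alike. Size alone does not sort these numbers either: a 1.4-fold higher number from compound 1 to compound 4 (0.15 log units; within the scatter) leaves methyl unseparated from the much larger 1-benzyl-1H-tetrazol-5-yl. Nothing shown here gives a reason for these differences. As far as these compounds go, whether an ethyl, a methoxy or a chlorine on this carbon would read like methyl or like cyano remains open.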